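Swapping the Benzyl Group of Compound 2

The source may report more compounds than this note shows. Statements on the series, on what has been measured and on what is new or still open speak of the compounds shown alone.

Compound 2 `Nc1cc(N)c2nc(-c3ccccc3)c(NCc3ccc(Cl)c(Cl)c3)nc2c1` stands lowest of the two numbers shown in a functional assay on SW-620 cells (Homo sapiens) for inhibition, read by sulforhodamine B assay, with a stated time of 48 h (on this read-out higher numbers stand for weaker inhibition of growth and lower numbers for stronger inhibition of growth), where compound 2 gives 9770 nM. Its nearest neighbour, compound 1 `Nc1cc(N)c2nc(-c3ccccc3)c(Oc3ccc(Cl)c(Cl)c3)nc2c1`, gives 30200 nM in this assay, a gap beyond the scatter. Compound 3 `CCOC(=O)[C@H](CCC(=O)O)NC(=O)c1ccc(Sc2nc3cc(N)cc(N)c3nc2-c2ccccc2)cc1` gives only a limit in this assay, < 100000 nM, and no number. Compound 4 `COc1ccc(CNc2nc3cc(N)cc(N)c3nc2-c2ccccc2)cc1` has not yet been measured; it differs from compound 2 by 4-methoxyphenyl in place of 3,4-dichlorophenyl on a saturated chain carbon bound to a nitrogen on an aromatic ring. Within the data shown here, no measured pair shows this change, so the step from compound 2 to compound 4 is expected to be modest, towards weaker inhibition of growth, a 2.0-fold higher number from compound 2 to compound 4 (0.31 log units; beyond the scatter). Compound 4 is therefore estimated at 20000 nM in this assay, within a range of 6000 nM to 70000 nM.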

Compound 4, concentration for total growth inhibition: 30200 nM
Compound 4: the middle estimate sits 1.5-fold (0.18 log units) below what was measured, and the stated range covers the measured number.
By their numbers in this assay, from the lowest: compound 2; then compounds 1 and 4 (each within the scatter of the next).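

In this assay, among these compounds, 4-methoxyphenyl in place of 3,4-dichlorophenyl gives a 3.1-fold higher number from compound 2 to compound 4 (0.49 log units; beyond the scatter), the first step that can be read at this place, on a saturated chain carbon bound to a nitrogen on an aromatic ring. Both groups hold the same count of heavy atoms, yet this one swap moves the number towards weaker inhibition of growth. No measurement shown here gives a reason for this step. As far as these compounds go, whether a plain phenyl, a 4-chlorophenyl or a longer chain at this place would stand nearer compound 2 or compound 4 remains open.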